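Phenyl for tert-butyl on two related cores

The source may hold more compounds than are shown below. What is called first, only, known or untested is meant among the compounds shown, and "the series" means these compounds.

Compound 3 `CC(C)(C)[C@@H](O)C(=O)N1N=CC[C@H]1C(=O)NCc1cc(Cl)ccc1-n1cnnn1` and compound 1 `O=C(NCc1cc(Cl)ccc1-n1cnnn1)[C@@H]1CC=NN1C(=O)[C@H](O)c1ccccc1` share one core; compound 2 `CC(C)(C)[C@@H](O)C(=O)N1OCC[C@H]1C(=O)NCc1cc(Cl)ccc1-n1cnnn1` and compound 4 `O=C(NCc1cc(Cl)ccc1-n1cnnn1)[C@@H]1CCON1C(=O)[C@H](O)c1ccccc1` share another. The difference between the two cores is not broken down here. In a functional assay on a cell-free system (plasma, Homo sapiens), with a stated time of 3 min (on this read-out lower numbers stand for stronger inhibition and higher numbers for weaker inhibition), compound 3 gives 1400 nM, and compound 1 gives 840 nM. The step of a 1.7-fold lower number from compound 3 to compound 1 (0.22 log units; within the scatter) corresponds to the change (phenyl in place of tert-butyl on a saturated chain carbon bound to a carbonyl carbon and an oxygen on a saturated carbon). In this assay compound 2 gives 1600 nM, which stands within the scatter of both compound 3 and compound 1.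

Compound 4 is not yet measured in this assay. It differs from compound 2 by phenyl in place of tert-butyl on a saturated chain carbon bound to a carbonyl carbon and an oxygen on a saturated carbon, the same change as that from compound 3 to compound 1. For the measured compounds named here, the change is expected to give about the same size of step, that is a 1.7-fold lower number from compound 2 to compound 4 (0.23 log units; within the scatter), resting on the single earlier instance, the step of a 1.7-fold lower number from compound 3 to compound 1 (0.22 log units; within the scatter), since that step sits within the scatter and only one pair shows it. Compound 4 is therefore estimated at 950 nM in this assay, with a range from 500 nM to 1900 nM expected.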

Compound 4, half-maximal inhibitory concentration: 1500 nM
Compound 4: the middle estimate sits 1.6-fold (0.20 log units) below what was measured; low and high end bracket the measured number.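

In this assay, phenyl in place of tert-butyl gives a 1.1-fold lower number from compound 2 to compound 4 (0.03 log units; within the scatter), so on this core the change moves the number by no more than repeated measurements would. Set beside the earlier instance on the core of compound 3, the two steps do not differ beyond what repeated measurement allows: the same change on two cores in this assay, a 1.7-fold lower number (0.22 log units; within the scatter) from compound 3 to compound 1 and a 1.1-fold lower number (0.03 log units; within the scatter) from compound 2 to compound 4, 1.6-fold (0.19 log units) apart, within the scatter of two such steps. This agrees with the change carrying from one core to the other without a detectable shift, but it does not show that the change has a real effect on either core, as both steps lie within the scatter, and two pairs set no rule for the series.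

The compounds shown carry only tert-butyl or phenyl on the saturated chain carbon bound to a carbonyl carbon and an oxygen, so it remains open whether a cyclohexyl or a pyridine ring there would move the number beyond the scatter. As far as these compounds go, it also remains open what an amine in place of the hydroxyl group would do on either core.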